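A few compounds are considered here, and "the series" means these few. Any claim that something is new, unique, unknown or untested is made for them only; others in the source may bear on it.

Measured so far in a functional assay on A-431 cells (Homo sapiens) for cytotoxicity, read by MTT assay, with a stated time of 48 h; on this read-out lower numbers stand for stronger inhibition and higher numbers for weaker inhibition:
compound 1 `CCCCCCCCCCCCCCNC(=O)[C@@H](NS(=O)(=O)c1cccs1)[C@@H](C)O`: 22000 nM
compound 2 `CCCCCCCCCCCCCCCCCCNC(=O)[C@@H](NC(=O)c1cc2ccccc2o1)[C@@H](C)O`: 78800 nM
compound 3 `CCCCCCCCCCCCCCCCCCNC(=O)[C@@H](NC(=O)c1nccc2ccccc12)[C@@H](C)O`: 44100 nM

Compound 3 sits between the other two on these numbers, but its value lies within the usual scatter of both compound 2 and compound 1, so the three compounds cannot be told apart by this assay. For the measured compounds named here, the only single-point step among them, a 1.8-fold lower number from compound 2 to compound 3 (0.25 log units; within the scatter), is likewise inside the scatter.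

Compound 4 `CCCCCCCCCCCCCCCCCCNC(=O)[C@@H](NS(=O)(=O)c1cccs1)[C@@H](C)O` is formed from compound 3 by (thiophen-2-yl)sulfonyl in place of (isoquinolin-1-yl)carbonyl on an amine nitrogen. Going by the values given here, no measured step covers this exact change. The closest guide is compound 1, which carries the same (thiophen-2-yl)sulfonyl group on a shorter chain and gives 22000 nM in this assay, a value inside the scatter of compound 3. Together with the flat picture across all three measured compounds, this gives no reason to expect a shift beyond the scatter. Compound 4 is therefore expected near 25000 nM, with a likely range from 10000 nM to 70000 nM, an estimated step of a 1.8-fold lower number from compound 3 to compound 4 (0.25 log units; within the scatter).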

Compound 4, half-maximal inhibitory concentration: > 200000 nM
Compound 4: a limit, no number; the forecaster's own chance of this, stated with the estimate: 5%; at least 8.0-fold (0.90 log units) between middle value and limit.
By their numbers in this assay, from the lowest: compounds 1, 3 and 2 (each within the scatter of the next, the first and the last beyond it). At a limit, above all of these: compound 4.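

Compound 4 gives a limit of the assay, not a number: the limit of > 200000 nM in this assay, at which 1 of the 4 values shown sits.

On the long chain, the group on the amine nitrogen does matter: (thiophen-2-yl)sulfonyl in place of (isoquinolin-1-yl)carbonyl gives an at least 4.5-fold higher number from compound 3 to compound 4 (0.65 log units; beyond the scatter), and in place of (1-benzofuran-2-yl)carbonyl it gives an at least 2.5-fold higher number from compound 2 to compound 4 (0.40 log units; beyond the scatter). With the sulfonyl group held fixed, butyl in place of hydrogen on the chain gives an at least 9.0-fold higher number from compound 1 to compound 4 (0.95 log units; beyond the scatter), so a change in the chain alone also moves this read-out beyond the scatter.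

The compounds shown leave open whether (isoquinolin-1-yl)carbonyl or (1-benzofuran-2-yl)carbonyl would respond to the shorter chain in the same way. They also leave open where a hexadecyl chain or a phenylsulfonyl group on the amine nitrogen would fall.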